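A few compounds are considered here, and "the series" means these few. Any claim that something is new, unique, unknown or untested is made for them only; others in the source may bear on it.

- compound 1 `Oc1ccc(-c2cc(-c3ccccc3)cc(-c3ccsc3)n2)cc1`: 1100 nM
- compound 2 `Oc1ccc(-c2cc(-c3ccccc3)cc(-c3cccnc3)n2)cc1`: 15100 nM
- compound 3 `Oc1ccccc1-c1cc(-c2ccccc2)nc(-c2ccco2)c1`: 2500 nM

In a functional assay on HCT-15 cells (Homo sapiens) for cytotoxicity, read by ELISA, with a stated time of 2 days (on this read-out lower numbers stand for stronger inhibition and higher numbers for weaker inhibition), compound 3 stands in the middle of these numbers, with compound 1 lower and compound 2 higher. Compound 4 `Oc1ccc(-c2cc(-c3ccccc3)nc(-c3ccco3)c2)cc1` has the same atoms as compound 3, joined differently: 4-hydroxyphenyl in place of 2-hydroxyphenyl on an aromatic carbon. Within the data shown here, the only measured step, a 14-fold higher number from compound 1 to compound 2 (1.14 log units; beyond the scatter), is large, but it concerns a different group. Among the measured compounds shown here, it shows that one swap can matter in these compounds, yet gives no direction for this one, and no measured pair tests this change. No step beyond the scatter is therefore expected in this assay, though the uncertainty is wide. The estimated step is no change at the digits printed from compound 3 to compound 4 (within the scatter). For compound 4 the expected value is 2500 nM, with an estimated range of 700 nM to 9000 nM.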

Compound 4, half-maximal inhibitory concentration: 5100 nM
Estimate against measurement, compound 4: 2.0-fold (0.31 log units) below; measured number inside the range.
By their numbers in this assay, from the lowest: compound 1; then compound 3; then compound 4; then compound 2.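

In this assay, 4-hydroxyphenyl in place of 2-hydroxyphenyl on the carbon opposite the ring nitrogen gives a 2.0-fold higher number from compound 3 to compound 4 (0.31 log units; beyond the scatter). The same atoms, joined differently, thus give a modest but readable change, so the place of the hydroxyl on this ring affects the number here. No measurement shown explains this difference. Still open, as far as these compounds go, is how 3-hydroxyphenyl, methoxyphenyl or aminophenyl would behave at this position, and whether a carboxylic acid could stand in place of the hydroxyl.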